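Thiophene for furan: the step from compound 3 to compound 4

The source may report more compounds than this note shows. Statements on the series, on what has been measured and on what is new or still open speak of the compounds shown alone.

Measured in a functional assay on Hep 3B2 cells (Homo sapiens) for cytotoxicity, read by MTT assay (on this read-out higher numbers stand for weaker inhibition and lower numbers for stronger inhibition), so far:
- compound 1 `COc1ccc(OC)c(C(=O)/C=C/c2ccco2)c1` gives 19000 nM
- compound 2 `COc1ccc(OC)c(C(=O)/C=C/c2cccs2)c1` gives 8400 nM
- compound 3 `COc1ccc(OC)c(C(=O)/C=C/c2ccc(C)o2)c1` gives 26500 nM

Compound 3 cannot be separated from compound 1 on these numbers, and it stands on the weaker side of compound 2, with a 3.2-fold higher number from compound 2 to compound 3 (0.50 log units; beyond the scatter) as the gap. The next structure is compound 4 `COc1ccc(OC)c(C(=O)/C=C/c2ccc(C)s2)c1`, and the change is 5-methylthiophen-2-yl in place of 5-methylfuran-2-yl on a double-bonded chain carbon bound to a double-bonded chain carbon, with 5-methylthiophen-2-yl in place of 5-methylfuran-2-yl on a double-bonded chain carbon bound to a double-bonded chain carbon. The closest measured precedent is the same ring exchange without the methyl, a 2.3-fold lower number from compound 1 to compound 2 (0.35 log units; beyond the scatter), which is modest but beyond the scatter. The methyl alone, a 1.4-fold higher number from compound 1 to compound 3 (0.14 log units; within the scatter), stays within the scatter. Going by the values given here, no measured pair yet tests the ring exchange with the methyl present. A lower number of similar size is therefore expected in this assay. The estimated move is a 2.3-fold lower number from compound 3 to compound 4 (0.36 log units; beyond the scatter) as things stand. Compound 4 is estimated at 11500 nM, with an expected range of 6000 nM to 22000 nM for now.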

Compound 4, half-maximal inhibitory concentration: 3400 nM
The estimate for compound 4 lay 3.4-fold (0.53 log units) above the measured number; the whole stated range lies above it.
By their numbers in this assay, from the lowest: compound 4; then compound 2; then compounds 1 and 3 (each within the scatter of the next).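

In this assay, the exchange of furan for thiophene does not carry over at one fixed size: with the methyl present it gives a 7.8-fold lower number from compound 3 to compound 4 (0.89 log units; beyond the scatter), larger than the step without the methyl, a 2.3-fold lower number from compound 1 to compound 2 (0.35 log units; beyond the scatter). On the thiophene side, methyl in place of hydrogen on an aromatic carbon now gives a 2.5-fold lower number from compound 2 to compound 4 (0.39 log units; beyond the scatter), and the two changes together give a 5.6-fold lower number from compound 1 to compound 4 (0.75 log units; beyond the scatter). The effect of the methyl therefore depends on the ring that carries it: the same change on two cores in this assay, a 1.4-fold higher number (0.14 log units; within the scatter) from compound 1 to compound 3 and a 2.5-fold lower number (0.39 log units; beyond the scatter) from compound 2 to compound 4, 3.4-fold (0.54 log units) apart, beyond the scatter of two such steps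

The compounds shown carry only hydrogen or methyl at this ring carbon, so it stays open whether an ethyl, a chlorine or a carboxylic acid there would follow compound 4 on the thiophene. Going by these compounds, whether the furan ring would respond to such groups as it does to methyl also stays open.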